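This account rests on a few compounds, and the source may have more. Where it says the series, first, only, none or still open, it means among the compounds named here.

Measured so far:
compound 1, `COc1ccc(CCCCCCCCOc2ccc(CSCc3cccc(C(=O)O)c3)nc2/C=C/C(=O)O)cc1`: 131 nM
compound 2, `COc1ccc(CCCCCCCCOc2ccc(CSCc3cccc(C(=O)O)c3)nc2CCC(=O)O)cc1`: 240 nM
compound 3, `COc1ccc(CCCCCCCCOc2ccc(CSCc3ccc(C(=O)O)cc3)nc2/C=C/C(=O)O)cc1`: 175 nM

In a functional assay on the whole organism with Homo sapiens as the target, read by calcium flux (a higher number here means a weaker inhibitor, a lower number a stronger inhibitor), compound 1 gives 131 nM, the lowest of the three numbers, though both other compounds sit within the scatter of it: a 1.3-fold higher number from compound 1 to compound 3 (0.13 log units; within the scatter) and a 1.8-fold higher number from compound 1 to compound 2 (0.26 log units; within the scatter). Compound 4, `COc1ccc(CCCCOc2ccc(CSCc3cccc(C(=O)O)c3)nc2/C=C/C(=O)O)cc1`, is not yet measured. It differs from compound 1 in one place: 4-methoxyphenyl in place of 4-(4-methoxyphenyl)butyl on a saturated chain carbon, four bonds along the chain from an oxygen on an aromatic ring. Neither measured step bears on this change; both alter groups carrying a carboxylic acid, while the chain leading to the oxygen on an aromatic ring is the same in every measured compound. No guide therefore exists for a shortened chain, and the expectation is a weaker inhibitor with a wide range, a 4.6-fold higher number from compound 1 to compound 4 (0.66 log units; beyond the scatter). Compound 4 is estimated at 600 nM, between 150 nM and 3000 nM.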

Compound 4, half-maximal inhibitory concentration: 770 nM
Beside the measured number, compound 4's estimate is 1.3-fold (0.11 log units) below it; measured number inside the range.
By their numbers in this assay, from the lowest: compounds 1, 3 and 2 (each within the scatter of the next); then compound 4.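

In this assay, for the compounds shown here, this position responds clearly to a change in the chain: 4-methoxyphenyl in place of 4-(4-methoxyphenyl)butyl brings a 5.9-fold higher number from compound 1 to compound 4 (0.77 log units; beyond the scatter), the only step here that lies beyond the scatter. The chain therefore matters more than the two changes to groups carrying a carboxylic acid, which both stayed within the scatter. Nothing available explains why the shorter chain gives a weaker inhibitor. Still open, going by these compounds, is how a chain longer than that of compound 1 would read, and whether an amine within the chain would keep the inhibition.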